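This account rests on a few compounds, and the source may have more. Where it says the series, first, only, none or still open, it means among the compounds named here.

Among the measured compounds shown here, compound 1, `COc1ccc2c(c1)CCCN2S(=O)(=O)c1ccc(N2CCCC2=O)cc1`, is one of two compounds with a number so far. In a functional assay on MCF7 cells (Homo sapiens) for antiproliferative activity, read by fluorescence and SYBR Green assay, with a stated time of 24 h (on this read-out lower numbers stand for stronger inhibition and higher numbers for weaker inhibition), compound 1 gives 25 nM. Compound 2, `COc1ccc2c(c1)N(C)CCN2S(=O)(=O)c1ccc(N2CCCC2=O)cc1`, gives 14 nM in this assay. Of these two numbers, that of compound 1 is the larger, but the gap to compound 2 lies within the usual scatter, so the two cannot be told apart on this evidence.

Compound 3, `O=C1CCCN1c1ccc(S(=O)(=O)N2CCCc3ccccc32)cc1`, is not yet measured. It differs from compound 1 in one place: hydrogen in place of methoxy on an aromatic carbon. For the measured compounds named here, no pair of measured compounds that differ in one place is available, so there is no measured step to lean on. The expectation is a modest move toward a higher number, of a size a 1.8-fold higher number from compound 1 to compound 3 (0.26 log units; within the scatter), close to the edge of the scatter. Compound 3 is therefore estimated at 45 nM, with a range from 15 nM to 140 nM.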

Compound 3, half-maximal inhibitory concentration: 17 nM
Compound 3: the middle estimate sits 2.6-fold (0.42 log units) above what was measured; the measured number falls inside the stated range.
By their numbers in this assay, from the lowest: compounds 2, 3 and 1 (each within the scatter of the next).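

Among the compounds shown here, replacing the methoxy group on this aromatic carbon with hydrogen gives a 1.5-fold lower number from compound 1 to compound 3 (0.17 log units; within the scatter) in this assay and is the first one-place step available in this set. It shows that, on the core of compound 1, a number in the same range is kept without the methoxy group, so compound 3 and compound 1 cannot be told apart at this position. No measurement offered here explains this result.

As far as these compounds go, it remains open whether a different group on this carbon, such as a hydroxyl, a fluorine atom or an amine, would shift the number beyond the scatter. From the compounds shown here alone, this is also a single pair, so whether hydrogen in place of methoxy behaves the same way on the core of compound 2 remains unknown.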